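Chloro for Methyl on the Benzylsulfanyl Arm

A few compounds are considered here, and "the series" means these few. Any claim that something is new, unique, unknown or untested is made for them only; others in the source may bear on it.

Compound 1 `Cc1cc(S(=O)(=O)/N=C(\N)n2nccc2-c2ccccc2)c(SCc2ccccc2C)cc1Cl` and compound 2 `Cc1ccc(CSc2cc(Cl)c(C)cc2S(=O)(=O)/N=C(\N)n2nccc2-c2ccccc2)cc1` share one core and differ only in the methylphenyl group: 2-methylphenyl in compound 1, 4-methylphenyl in compound 2. In a functional assay on HeLa cells (Homo sapiens) for cytotoxicity, read by MTT assay, with a stated time of 72 h (a lower number here means a stronger inhibitor, a higher number a weaker inhibitor), compound 1 gives 17000 nM, and compound 2 gives 17000 nM; the step of no change at the digits printed from compound 1 to compound 2 (within the scatter) lies within the scatter, so compound 2 stands level with compound 1 on these numbers. Compound 3 `Cc1cc(S(=O)(=O)/N=C(\N)n2nccc2-c2ccccc2)c(SCc2ccc(Cl)cc2)cc1Cl` is the next variant: chloro in place of methyl on an aromatic carbon. Going by the values given here, no measured step exchanges a methyl for a chloro, so the single step from compound 1 to compound 2 is the only guide, and it shows that a change on this benzyl ring left this assay unchanged. On that slender basis a step of no size beyond the scatter is expected in this assay, with no direction favoured, no change at the digits printed from compound 2 to compound 3 (within the scatter). Compound 3 is therefore estimated at 17000 nM in this assay, with a range of 6000 nM to 45000 nM.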

Compound 3, half-maximal inhibitory concentration: 3000 nM
Compound 3: middle estimate off by 5.7-fold (0.75 log units), on the high side, and the stated range ends above it.
By their numbers in this assay, from the lowest: compound 3; then compounds 1 and 2 (each within the scatter of the next).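

In this assay chloro in place of methyl, para to a large group on the benzyl ring, gives a 5.7-fold lower number from compound 2 to compound 3 (0.75 log units; beyond the scatter) and the change from 2-methylphenyl to 4-chlorophenyl gives a 5.7-fold lower number from compound 1 to compound 3 (0.75 log units; beyond the scatter) in the same direction. The earlier pair showed only that moving the methyl left the number level; compound 3 shows that this ring can register a change in this read-out when the group itself is exchanged, and that compounds 1 and 2 do not mark a floor for the series. The data offer no measured reason for this step.

The compounds shown leave open whether the gain is particular to chloro or would also appear with bromo, methoxy or a nitrile at this place. They also leave open whether the same exchange would carry over to a different core.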